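Moving the Methoxy Group in a Sulfonamide Benzamide Series

The source may hold more compounds than are shown below. What is called first, only, known or untested is meant among the compounds shown, and "the series" means these compounds.

The account covers three measured compounds and one that awaits measurement. Compound 1 `COc1ccc(-n2cc(NC(=O)c3cccc(NS(=O)(=O)c4ccccc4)c3)cn2)cc1` is tested in a functional assay on HepG2 cells (Homo sapiens) for inhibition, read by MTT assay, with a stated time of 48 h (a lower number here means a stronger inhibitor, a higher number a weaker inhibitor), where compound 1 gives 35700 nM. Compound 2 `COc1cccc(-n2cc(NC(=O)c3cccc(NS(=O)(=O)c4ccccc4)c3)cn2)c1` differs from it by 3-methoxyphenyl in place of 4-methoxyphenyl on an aromatic nitrogen, and in this assay compound 2 gives 25000 nM. Compound 3 `COc1ccc(-n2cc(NC(=O)c3cccc(NS(=O)(=O)c4ccc(Cl)cc4)c3)cn2)cc1` carries instead (chloro in place of hydrogen on an aromatic carbon), and in this assay compound 3 gives 15200 nM.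

Between the measured pairs, the move of the methoxy group gave a 1.4-fold lower number from compound 1 to compound 2 (0.15 log units; within the scatter). The chloro gave a 2.3-fold lower number from compound 1 to compound 3 (0.37 log units; beyond the scatter). Compound 3 thus shows the lowest number of the three, though its gap to compound 2 lies within the scatter and only its gap to compound 1 lies beyond it.

Compound 4 `COc1cccc(-n2cc(NC(=O)c3cccc(NS(=O)(=O)c4ccc(Cl)cc4)c3)cn2)c1` remains to be measured. It differs from compound 3 by 3-methoxyphenyl in place of 4-methoxyphenyl on an aromatic nitrogen, the same change that separates compound 1 from compound 2, and it shares with compound 3 the core that differs from that of compound 1 by chloro in place of hydrogen on an aromatic carbon. Since the place of the change is described in the same terms in both pairs, the author treats it as the same change.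

The step of a 1.4-fold lower number from compound 3 to compound 4 (0.14 log units; within the scatter) is expected to be small, because the matching change gave a 1.4-fold lower number from compound 1 to compound 2 (0.15 log units; within the scatter). For compound 4 the estimate in this assay is 11000 nM. For compound 4 the expected range runs from 5000 nM to 28000 nM.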

Compound 4, half-maximal inhibitory concentration: 19600 nM
Compound 4: middle estimate off by 1.8-fold (0.25 log units), on the low side; low and high end bracket the measured number.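

In this assay, the move from 4-methoxyphenyl to 3-methoxyphenyl on the chloro-bearing core gave a 1.3-fold higher number from compound 3 to compound 4 (0.11 log units; within the scatter), and chloro in place of hydrogen on the core of compound 2 gave a 1.3-fold lower number from compound 2 to compound 4 (0.11 log units; within the scatter). Set beside the earlier step, the methoxy move shows no difference between the two cores that can be told from the scatter: the same change on two cores in this assay, a 1.4-fold lower number (0.15 log units; within the scatter) from compound 1 to compound 2 and a 1.3-fold higher number (0.11 log units; within the scatter) from compound 3 to compound 4, 1.8-fold (0.27 log units) apart, within the scatter of two such steps The chloro step likewise shows no such difference, but this does not establish that either change has the same effect on both cores, only that these four compounds cannot separate the two steps in each pair: the same change on two cores in this assay, a 2.3-fold lower number (0.37 log units; beyond the scatter) from compound 1 to compound 3 and a 1.3-fold lower number (0.11 log units; within the scatter) from compound 2 to compound 4, 1.8-fold (0.27 log units) apart, within the scatter of two such steps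

The compounds shown leave open whether this holds for other groups on the same phenyl ring, such as an amine or a carboxylic acid in place of the methoxy group, or for a bromo or a trifluoromethyl group in place of the chloro. As far as these compounds go, it also remains open whether the steps would read the same way on any other cell line.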